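Benzyl Ether Substituent Exchange in a Colon Cell Assay

A few compounds are considered here, and "the series" means these few. Any claim that something is new, unique, unknown or untested is made for them only; others in the source may bear on it.

Measured compounds in a functional assay on SW-620 cells (Homo sapiens) for inhibition, read by MTT assay, with a stated time of 48 h; on this read-out higher numbers stand for weaker inhibition and lower numbers for stronger inhibition:
compound 1 `Cc1ccc(NC(=S)NC(=O)c2ccc(OCc3ccccc3)cc2)cc1-c1nc2ccccc2[nH]1` gives 67100 nM;
compound 2 `Cc1ccc(NC(=S)NC(=O)c2ccc(OCc3ccc(C(F)(F)F)cc3)cc2)cc1-c1nc2ccccc2[nH]1` gives 72400 nM;
compound 3 `Cc1ccc(COc2ccc(C(=O)NC(=S)Nc3ccc(C)c(-c4nc5ccccc5[nH]4)c3)cc2)cc1` gives 60900 nM.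

Compound 2 stands with both neighbours inside the usual scatter: the step of a 1.1-fold higher number from compound 1 to compound 2 (0.03 log units; within the scatter) and the step of a 1.2-fold lower number from compound 2 to compound 3 (0.08 log units; within the scatter) are small, as is a 1.1-fold lower number from compound 1 to compound 3 (0.04 log units; within the scatter). Compound 4 `Cc1ccc(NC(=S)NC(=O)c2ccc(OCc3cccc(F)c3)cc2)cc1-c1nc2ccccc2[nH]1` differs from compound 2 by 3-fluorophenyl in place of 4-(trifluoromethyl)phenyl on a saturated chain carbon bound to an oxygen on an aromatic ring. The measured steps that bear on this change are the two that altered the same benzyl group, a 1.1-fold higher number from compound 1 to compound 2 (0.03 log units; within the scatter) and a 1.2-fold lower number from compound 2 to compound 3 (0.08 log units; within the scatter), and neither moved the read-out beyond the scatter. Among the compounds with values here, no measured step therefore supports a shift beyond the scatter in this assay, and the expected step of a 1.1-fold lower number from compound 2 to compound 4 (0.04 log units; within the scatter) reflects that. Compound 4 is estimated at 66000 nM, with a range from 35000 nM to 125000 nM.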

Compound 4, half-maximal inhibitory concentration: > 100000 nM
Compound 4 gave a limit, no number; the forecaster's own chance of this, stated with the estimate: 10%; middle value at least 1.5-fold (0.18 log units) from the limit.
By their numbers in this assay, from the lowest: compounds 3, 1 and 2 (each within the scatter of the next). At a limit, above all of these: compound 4.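

In this assay compound 4 gives a limit, not a number: the limit of > 100000 nM in this assay, at which 1 of the 4 values shown sits. The steps of an at least 1.3-fold higher number from compound 2 to compound 4 (0.14 log units; that floor lies within the scatter), an at least 1.6-fold higher number from compound 3 to compound 4 (0.21 log units; that floor lies within the scatter) and an at least 1.4-fold higher number from compound 1 to compound 4 (0.17 log units; that floor lies within the scatter) are floors only, so the true steps may be larger. This change on the benzyl group is thus the first at this position whose size stays open upward, although no step here is yet shown to lie beyond the scatter.

The compounds shown leave open how far compound 4 truly lies from the others. They also leave open whether an amine or a carboxylic acid on this benzyl ring would shift the read-out beyond the scatter.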